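A few compounds are considered here, and "the series" means these few. Any claim that something is new, unique, unknown or untested is made for them only; others in the source may bear on it.

Measured so far in a functional assay on B16-F10 cells (Mus musculus) for antiproliferative activity, read by MTT assay, with a stated time of 48 h; on this read-out lower numbers stand for stronger inhibition and higher numbers for weaker inhibition:

- Compound 1 `O=C(/C=C/c1ccc(O)c(O)c1)N1CCN(c2ccccc2Cl)CC1`: 1.82 ug/mL
- Compound 2 `COc1cccc(N2CCN(C(=O)/C=C/c3ccc(O)c(O)c3)CC2)c1`: 1.46 ug/mL
- Compound 3 `Cc1ccc(N2CCN(C(=O)/C=C/c3ccc(O)c(O)c3)CC2)c(C)c1`: 1.43 ug/mL

All three compounds share one core and differ only in the aromatic group on an amine nitrogen in a ring. In this assay compound 3 gives 1.43 ug/mL, a number that cannot be told apart from those of the other two compounds, since repeat measurements of this kind scatter by more than these gaps.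

The next compound is compound 4 `O=C(/C=C/c1ccc(O)c(O)c1)N1CCN(c2ccc(Cl)c(Cl)c2)CC1`, which changes that same group: 3,4-dichlorophenyl in place of 2,4-dimethylphenyl on an amine nitrogen in a ring. Going by the values given here, three measured steps bear on this change, because each swaps the group at this place: a 1.2-fold lower number from compound 1 to compound 2 (0.10 log units; within the scatter), a 1.3-fold lower number from compound 1 to compound 3 (0.10 log units; within the scatter) and a 1.0-fold lower number from compound 2 to compound 3 (0.01 log units; within the scatter). All three stay within the scatter, across chloro, methoxy and dimethyl groups. Among the compounds with values here, no measured compound carries the 3,4-dichlorophenyl group, although compound 1 does carry a 2-chlorophenyl group. Three compounds are a thin basis, so a surprise remains possible, but no change beyond the scatter is expected in this assay.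

The expected change is a 1.1-fold higher number from compound 3 to compound 4 (0.05 log units; within the scatter).

For compound 4 the estimate is 1.6 ug/mL, with an expected range from 0.8 ug/mL to 3 ug/mL.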

Compound 4, half-maximal inhibitory concentration: 1.66 ug/mL
The estimate for compound 4 lay 1.0-fold (0.02 log units) below the measured number, and the stated range covers the measured number.
By their numbers in this assay, from the lowest: compounds 3, 2, 4 and 1 (each within the scatter of the next).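

With compound 4, the aromatic group on the amine nitrogen in a ring carries two chlorine atoms, and in this assay the steps to it stay small (a 1.2-fold higher number from compound 3 to compound 4 (0.06 log units; within the scatter)) and (a 1.1-fold higher number from compound 2 to compound 4 (0.06 log units; within the scatter)) and (a 1.1-fold lower number from compound 1 to compound 4 (0.04 log units; within the scatter)). The last of these compares two chlorine-bearing groups, and even there the 2-chlorophenyl and 3,4-dichlorophenyl groups cannot be told apart. All four aromatic groups shown, with chloro, methoxy or methyl substituents, now give numbers within the scatter of one another, and no outside evidence offers a reason for this.

Every group shown at this place is a substituted phenyl ring, so it remains open whether an unsubstituted phenyl, a phenyl carrying a carboxylic acid or an amine, or a plain alkyl chain on that nitrogen would move the number beyond the scatter. From the compounds shown here alone, the shared core stays the same throughout, so what a change there would do, such as methoxy groups in place of its two hydroxyl groups, also stays open.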